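The source may hold more compounds than are shown below. What is called first, only, known or untested is meant among the compounds shown, and "the series" means these compounds.

Among the measured compounds shown here, compound 1 `Nc1nc(-c2ccc(CO)cc2)nc2sc(-c3ccccc3)nc12` is the first of the set. In an assay on CHO cells for displacement of a labelled ligand from adenosine receptor A3 (Homo sapiens), read by scintillation counting, with a stated time of 3 h (on this read-out lower numbers stand for stronger inhibition and higher numbers for weaker inhibition), compound 1 gives 8.2 nM. Compound 2 `COc1ccc(-c2nc(N)c3nc(-c4ccccc4)sc3n2)cc1` differs from it in one place only, (methoxy in place of hydroxymethyl on an aromatic carbon), and in this assay compound 2 gives 46.7 nM. That swap produced a 5.7-fold higher number from compound 1 to compound 2 (0.76 log units; beyond the scatter), a modest but real loss of binding. Compound 3 `Nc1nc(-c2cccc(CO)c2)nc2sc(-c3ccco3)nc12` carries a different core; how that core differs from the core of compound 1 is not broken down here. In this assay compound 3 gives 0.9 nM, the lowest of the three numbers. Compound 4 `COc1cccc(-c2nc(N)c3nc(-c4ccco4)sc3n2)c1` has not yet been measured. It differs from compound 3 by methoxy in place of hydroxymethyl on an aromatic carbon. For the measured compounds named here, this is the same kind of change as the one made between compound 1 and compound 2, though the surroundings differ: in compound 2 the methoxy sits para to a large group, whereas in compound 4 it sits meta to a large group. The expectation for compound 4 rests on the earlier step, a 5.7-fold higher number from compound 1 to compound 2 (0.76 log units; beyond the scatter), and is a step of about a 5.6-fold higher number from compound 3 to compound 4 (0.74 log units; beyond the scatter). In this assay compound 4 is therefore expected to give 5 nM, most likely between 1.5 nM and 15 nM.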

Compound 4, inhibition constant: 4.9 nM
Compound 4: the middle estimate sits 1.0-fold (0.01 log units) above what was measured; the range from low to high includes it.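

In this assay, replacing hydroxymethyl with methoxy gives a 5.4-fold higher number from compound 3 to compound 4 (0.74 log units; beyond the scatter), so compound 4 binds less well than compound 3. Set beside the earlier step, the size of this loss carries over from one core to the other, even though the surroundings of the group differ between the two pairs: the same change on two cores in this assay, a 5.7-fold higher number (0.76 log units; beyond the scatter) from compound 1 to compound 2 and a 5.4-fold higher number (0.74 log units; beyond the scatter) from compound 3 to compound 4, 1.0-fold (0.02 log units) apart, within the scatter of two such steps These are only two pairs, however, so the agreement holds for these two cores and is not a rule for the series, and it does not show why the swap weakens binding or how it would behave on a third core.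

Both pairs compare only hydroxymethyl and methoxy, which leaves open how another group in the same place, such as an amine, a carboxylic acid or a longer chain, would read on either core. Also open, on these data alone, is whether the step keeps its size in any other assay, since all four compounds are compared here on a single receptor.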